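Methyl to Hydrogen on an Aromatic Oxygen, Two Cores

The source may hold more compounds than are shown below. What is called first, only, known or untested is meant among the compounds shown, and "the series" means these compounds.

Measured so far in a functional assay on U-373MG ATCC cells (Homo sapiens) for inhibition, read by colorimetric assay and MTT assay, with a stated time of 72 h; a lower number here means a stronger inhibitor, a higher number a weaker inhibitor:
compound 1, `COc1ccc(C(=O)NNC(=S)Nc2csc(-c3ccc(C)cc3)c2)cc1`, gives 19000 nM
compound 2, `Cc1ccc(-c2cc(NC(=S)NNC(=O)c3ccc(O)cc3)cs2)cc1`, gives 64000 nM
compound 3, `COc1ccc(-c2nnc(Nc3csc(-c4ccccc4)c3)s2)cc1`, gives 92000 nM

Compounds 1 and 2 share one core, while compound 3 is built on another; the difference between the two cores is not broken down here. Compound 4, `Oc1ccc(-c2nnc(Nc3csc(-c4ccccc4)c3)s2)cc1`, has not yet been measured.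

Between compound 1 and compound 2 the change is hydrogen in place of methyl on an oxygen on an aromatic ring. That change made a 3.4-fold higher number from compound 1 to compound 2 (0.53 log units; beyond the scatter). From compound 3 to compound 4 the change is hydrogen in place of methyl on an oxygen on an aromatic ring, the same change at the same place, only carried out on the other core. One earlier example is all there is, so the expectation rests on a single measured step.

For compound 4 in this assay the expected step is a 2.7-fold higher number from compound 3 to compound 4 (0.43 log units; beyond the scatter), set beside the measured step from compound 1 to compound 2. Compound 4 is therefore expected to give about 250000 nM, most likely between 100000 nM and 700000 nM, and a result reported only as a limit would not be surprising.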

Compound 4, half-maximal inhibitory concentration: 58000 nM
Estimate against measurement, compound 4: 4.3-fold (0.63 log units) above, and the stated range ends above it.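

Going from methoxy to hydroxy on the core of compound 3 gives a 1.6-fold lower number from compound 3 to compound 4 (0.20 log units; within the scatter) in this assay, so on this core the two compounds cannot be told apart. Set beside the earlier step, this shows that the same change did not have the same size of effect on the two cores, and that a step measured on one core was a poor guide to the step on the other: the same change on two cores in this assay, a 3.4-fold higher number (0.53 log units; beyond the scatter) from compound 1 to compound 2 and a 1.6-fold lower number (0.20 log units; within the scatter) from compound 3 to compound 4, 5.3-fold (0.73 log units) apart, beyond the scatter of two such steps With only one measured step on each core, this does not show why the cores differ, nor how either core would respond to any other change at this place.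

Still open, from the compounds shown here alone, is whether an amine or a carboxylic acid in place of the methoxy group, or a longer chain on the oxygen, would also depend on the core. The four compounds also leave open whether the difference between the two steps would hold in any test other than this assay.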